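Methyl to Ethyl in a Series Sitting at the Limit

This account rests on a few compounds, and the source may have more. Where it says the series, first, only, none or still open, it means among the compounds named here.

Compound 2 `Cc1nnc(SCC(=O)c2ccccc2)n1N1C(=O)c2ccccc2C1=O` carries a benzoyl on a saturated chain carbon bound to a sulfur. In a functional assay on A549 cells (Homo sapiens) for cytotoxicity, read by MTT assay, with a stated time of 48 h (on this read-out lower numbers stand for stronger inhibition and higher numbers for weaker inhibition), compound 2 gives only a limit, > 200000 nM. Compound 1 `Cc1nnc(SCc2ccccc2)n1N1C(=O)c2ccccc2C1=O` likewise returns a limit in this assay, > 200000 nM. Compound 3 `Cc1nnc(SCc2ccccc2Cl)n1N1C(=O)c2ccccc2C1=O` also sits at a limit in this assay, > 200000 nM. The steps a step that the two limits leave unreadable from compound 1 to compound 2, a step that the two limits leave unreadable from compound 1 to compound 3 and a step that the two limits leave unreadable from compound 2 to compound 3 therefore carry no readable size, and the limit of > 200000 nM in this assay, at which 3 of the 3 values shown sit, is all the measured set shows. Compound 4 `CCc1nnc(SCC(=O)c2ccccc2)n1N1C(=O)c2ccccc2C1=O` differs from compound 2 by methyl in place of hydrogen on a saturated chain carbon bound to an aromatic carbon. Among the compounds with values here, no measured step bears on this change, so compound 4 is expected to remain at the limit, a step that the limit leaves unreadable from compound 2 to compound 4. The value of compound 4 in this assay is estimated at 300000 nM, between 150000 nM and 1000000 nM.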

Compound 4, half-maximal inhibitory concentration: > 200000 nM
Compound 4 gave a limit, no number (the forecaster's own chance of this, stated with the estimate: 85%); the middle value is on the limit's open side.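

No new step can be read between compound 2 and compound 4, since both give only a limit: the limit of > 200000 nM in this assay, at which 4 of the 4 values shown sit.

The compounds shown leave open how far any of them lies beyond that limit, and whether methyl to ethyl changes anything.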